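From furan-3-yl to 2-phenylethenyl on a shared core

The compounds below may be only part of what the source reports. "The series", "measured", "known", "first", "only" and "open" are said of these compounds alone.

Measured in a functional assay on K562 cells (Homo sapiens) for antiproliferative activity, with a stated time of 72 h; a higher number here means a weaker inhibitor, a lower number a stronger inhibitor:
- compound 1 `CCCC#Cc1cc([C@@H]2O[C@H](CO)[C@@H](O)[C@H]2O)n2ncnc(N)c12`: 1100 nM
- compound 2 `Nc1ncnn2c([C@@H]3O[C@H](CO)[C@@H](O)[C@H]3O)cc(-c3ccoc3)c12`: 2100 nM

On these numbers compound 2 does not stand apart. Among the compounds with values here, the only measured step is a 1.9-fold higher number from compound 1 to compound 2 (0.28 log units; within the scatter). Compound 3 `Nc1ncnn2c([C@@H]3O[C@H](CO)[C@@H](O)[C@H]3O)cc(/C=C/c3ccccc3)c12` changes the same aromatic carbon again: 2-phenylethenyl in place of furan-3-yl on an aromatic carbon. That single step swapped one group for another at this place and stayed within the scatter, so no change beyond the scatter is expected in this assay, though one step is thin evidence. The expected result is a 1.2-fold lower number from compound 2 to compound 3 (0.07 log units; within the scatter). For compound 3 the estimated value is 1800 nM, with an expected range of 600 nM to 6000 nM.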

Compound 3, half-maximal inhibitory concentration: 3100 nM
Beside the measured number, compound 3's estimate is 1.7-fold (0.24 log units) below it; the measured number falls inside the stated range.
By their numbers in this assay, from the lowest: compounds 1, 2 and 3 (each within the scatter of the next, the first and the last beyond it).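

In this assay, putting 2-phenylethenyl in place of furan-3-yl gives a 1.5-fold higher number from compound 2 to compound 3 (0.17 log units; within the scatter), so this aromatic carbon accepts a group of 8 heavy atoms without a change beyond the scatter. Putting it in place of pent-1-yn-1-yl gives a 2.8-fold higher number from compound 1 to compound 3 (0.45 log units; beyond the scatter), a modest step and the first here to pass the scatter. Nothing available explains either step. On these data alone, what remains open is how an amine or a carboxylic acid on this carbon would compare, and whether a longer chain than pent-1-yn-1-yl would shift the number.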